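A few compounds are considered here, and "the series" means these few. Any claim that something is new, unique, unknown or untested is made for them only; others in the source may bear on it.

In an ADME assay on microsomes from liver (Mus musculus, strain CD1) for metabolic stability, read by LC-MS, using NADPH, with a stated time of 60 min (a lower number here means that the compound disappears faster, a higher number that the compound lasts longer), compound 1 `N=c1c2c(-c3ccccc3)c(-c3ccccc3)n(Cc3ccccc3)c2ncn1C1CCN(Cc2ccccc2)CC1` gives 0.537 h and compound 2 `COc1ccc(-c2c(-c3ccc(OC)cc3)n(Cc3ccccc3)c3ncn(CCCO)c(=N)c23)cc1` gives 0.36 h; these two half-lives lie within the scatter of each other, so neither can be set apart from the other. Compound 3 `COc1ccc(-c2c(-c3ccc(OC)cc3)n(Cc3ccccc3)c3ncn(CCO)c(=N)c23)cc1` differs from compound 2 by hydroxy in place of hydroxymethyl on a saturated chain carbon, two bonds along the chain from an aromatic nitrogen. Going by the values given here, no measured pair shows this change, and the two numbers already seen give no ground for a shift beyond the scatter in either direction. The step for compound 3 is expected to be small, a 1.1-fold higher number from compound 2 to compound 3 (0.05 log units; within the scatter). Compound 3 is estimated at 0.4 h, with a range from 0.2 h to 0.8 h.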

Compound 3, half-life: 1.22 h
The estimate for compound 3 lay 3.1-fold (0.48 log units) below the measured number, and the stated range ends below it.
By their numbers in this assay, from the lowest: compounds 2 and 1 (each within the scatter of the next); then compound 3.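

Going from 3-hydroxypropyl to 2-hydroxyethyl on the aromatic nitrogen, with the rest of the molecule unchanged, gives a 3.4-fold higher number from compound 2 to compound 3 (0.53 log units; beyond the scatter) in this assay. The first two compounds differed in several places and could not show this; here the loss of a single carbon from the chain is enough to move the half-life. Nothing at hand explains the size of this step. From the compounds shown here alone, it remains open whether the half-life keeps changing with a hydroxymethyl group or a longer chain at this place, and what an amine or a carboxylic acid would do in place of the hydroxy. Going by these compounds, whether the step carries over to the other substituents of the core also stays unknown.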